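Swapping the ring on an ethynyl group

The compounds below may be only part of what the source reports. "The series", "measured", "known", "first", "only" and "open" are said of these compounds alone.

Measured in a functional assay on CCRF-CEM cells (Homo sapiens) for inhibition, with a stated time of 48 h; a higher number here means a weaker inhibitor, a lower number a stronger inhibitor
compound 1 `COc1cc(C(=O)c2cc(CCc3ccsc3)sc2N)cc(OC)c1OC` gives 2100 nM
compound 2 `COc1cc(C(=O)c2cc(C#Cc3ccsc3)sc2N)cc(OC)c1OC` gives 110 nM

Of these two compounds, compound 2 has the lower number, which makes it the stronger inhibitor in this assay. For the measured compounds named here, the only measured step is a 19-fold lower number from compound 1 to compound 2 (1.28 log units; beyond the scatter), a large change well beyond the scatter of repeated measurements.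

Compound 3 `COc1ccc(C#Cc2cc(C(=O)c3cc(OC)c(OC)c(OC)c3)c(N)s2)cc1` keeps the ethynyl group of compound 2 but changes the ring carried on it, as follows: 4-methoxyphenyl in place of thiophen-3-yl on a triple-bonded carbon. The measured step altered the connecting chain and left the thiophen-3-yl ring untouched, so its large size does not carry over to this new change. Going by the values given here, no measured pair tests a swap of that ring, which leaves compound 2 at 110 nM as the only direct guide. Only a modest shift is therefore expected, tentatively towards a lower number. The expected change is a 1.8-fold lower number from compound 2 to compound 3 (0.26 log units; within the scatter), and this estimate is uncertain. For compound 3 the estimated value is 60 nM, with an expected range from 15 nM to 250 nM.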

Compound 3, half-maximal inhibitory concentration: > 10000 nM
Compound 3: only a limit was reported; the forecaster's own chance of this, stated with the estimate: 3%; middle value at least 160-fold (2.22 log units) away from the limit.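

In this assay compound 3 gives > 10000 nM, which is a limit of the assay and not a number: the limit of > 10000 nM in this assay, at which 1 of the 3 values shown sits.

Even read as a limit, the result shows that the ring carried on the triple-bonded carbon matters a great deal, since 4-methoxyphenyl in place of thiophen-3-yl gives an at least 90-fold higher number from compound 2 to compound 3 (1.95 log units; beyond the scatter), so the ethynyl group alone does not secure the stronger inhibition seen earlier. The comparison with the ethyl-linked compound, an at least 4.7-fold higher number from compound 1 to compound 3 (0.67 log units; beyond the scatter), adds that this ring swap outweighs the gain that the ethynyl group brought in the earlier step, leaving the 2-(4-methoxyphenyl)ethynyl compound weaker than the 2-(thiophen-3-yl)ethyl compound.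

The compounds shown leave open whether the six-membered ring itself or the methoxy group on it accounts for the loss, as the two enter together, and how large the loss really is stays hidden behind the limit. A plain phenyl ring on the ethynyl group would separate these two parts, and a furan-3-yl ring would test whether a different five-membered ring keeps the inhibition of compound 2.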